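The source may hold more compounds than are shown below. What is called first, only, known or untested is meant among the compounds shown, and "the series" means these compounds.

In an ADME assay on microsomes from liver (Mus musculus) for metabolic stability (on this read-out higher numbers stand for fast clearance and lower numbers for slow clearance), three compounds have been measured:

Compound 1 `CC(C(=O)O)c1nn(Cc2cn3cc(OCC4CC4)c(Cl)cc3n2)c2ccccc2c1=O`: 80 mL/min/kg.
Compound 2 `COc1cc(OC)c(NC(=O)Cc2cn(C)c3ccccc23)cc1Cl`: 4050 mL/min/kg.
Compound 3 `CC(C(=O)O)c1nn(Cc2cn3cc(OCC4CC4)c(C(F)(F)F)cc3n2)c2ccccc2c1=O`: < 60 mL/min/kg, a limit and not a number.

Compound 1 at 80 mL/min/kg gives the lower of the two actual numbers, well under compound 2 at 4050 mL/min/kg. Compound 3 sits at the limit of < 60 mL/min/kg in this assay, at which 1 of the 3 values shown sits.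

Compound 4 `C[C@H](C(=O)O)c1nn(Cc2cn3cc(OCC4CC4)c(Cl)cc3n2)c2ccccc2c1=O` differs from compound 1 only at one stereocentre: the two compounds have the same atoms and bonds; at least one stereo element is drawn with a configuration in one of them and without one in the other: 1 of 1 stereo elements differ; a stereocentre at a saturated chain carbon is drawn without a configuration in compound 1 and S in compound 4. Among the compounds with values here, the sole measured step, an at least 1.3-fold lower number from compound 1 to compound 3 (0.12 log units; that floor lies within the scatter), exchanges chloro for trifluoromethyl, stays within the scatter and leaves that stereocentre undrawn, so it bears only indirectly. No step beyond the scatter is expected in this assay. The expected change is a 1.1-fold lower number from compound 1 to compound 4 (0.03 log units; within the scatter). Compound 4 is estimated at 75 mL/min/kg, with an expected range of 45 mL/min/kg to 130 mL/min/kg.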

Compound 4, clearance: < 53.4 mL/min/kg
Compound 4: no number, only a limit (the forecaster's own chance of this, stated with the estimate: 30%); middle value at least 1.4-fold (0.14 log units) from the limit.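

Within the data shown here, compound 4 gives only a limit in this assay, not a number: the limit of < 53.4 mL/min/kg in this assay, at which 1 of the 4 values shown sits. Drawing this stereocentre as S gives an at least 1.4-fold lower number from compound 1 to compound 4 (0.17 log units; that floor lies within the scatter), so this change is the first at this position to be read, and nothing shows a shift beyond the scatter. Nothing else separates the pair: the fact that one of compounds 1 and 4 is drawn with a defined configuration and the other without, at the place where they differ

Going by these compounds, the opposite configuration at this stereocentre remains open, as does the true number behind the limit of compound 4. Also open, on these data alone, is how this assay would respond to an amide in place of the carboxylic acid, or to a longer chain at this carbon.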